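This account rests on a few compounds, and the source may have more. Where it says the series, first, only, none or still open, it means among the compounds named here.

In an ADME assay on Vero cells (Chlorocebus sabaeus) for cytotoxicity, read by fluorescence and resazurin assay, with a stated time of 3 days (a higher number here means that more compound is tolerated, a lower number that less compound is tolerated), compound 1 `CC1(C)O[C@H]2O[C@H](Cn3cc(CN4C(=O)/C(=N\Nc5ccc(Br)cc5)c5ccccc54)nn3)[C@H](O)[C@H]2O1` gives 72900 nM while compound 2 `COc1ccc(N/N=C2\C(=O)N(Cc3cn(C[C@H]4O[C@@H]5OC(C)(C)O[C@@H]5[C@H]4O)nn3)c3ccccc32)cc1` gives 74500 nM and compound 3 `CC1(C)O[C@H]2O[C@H](Cn3cc(CN4C(=O)/C(=N\Nc5ccc(C#N)cc5)c5ccccc54)nn3)[C@H](O)[C@H]2O1` gives 105000 nM with all three within the scatter of each other. Compound 3 therefore holds no separate place among them. Compound 4 `CC1(C)O[C@H]2O[C@H](Cn3cc(CN4C(=O)/C(=N\Nc5cccc(Cl)c5)c5ccccc54)nn3)[C@H](O)[C@H]2O1` differs from it in one place (3-chlorophenyl in place of 4-cyanophenyl on an amine nitrogen) with 3-chlorophenyl in place of 4-cyanophenyl on an amine nitrogen. Going by the values given here, the steps that bear on this are the exchanges on the same aromatic ring, namely a 1.0-fold higher number from compound 1 to compound 2 (0.01 log units; within the scatter) and a 1.4-fold higher number from compound 1 to compound 3 (0.16 log units; within the scatter) and a 1.4-fold higher number from compound 2 to compound 3 (0.15 log units; within the scatter) and all of them are small. None of them tests a 3-chlorophenyl group. The expected step is a 1.3-fold lower number from compound 3 to compound 4 (0.12 log units; within the scatter) and nothing beyond the scatter is anticipated in this assay here. Compound 4 is estimated at 80000 nM (expected range 45000 nM to 135000 nM).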

Compound 4, half-maximal cytotoxic concentration: 70000 nM
For compound 4 the middle estimate is 1.1-fold (0.06 log units) above the measured one; low and high end bracket the measured number.
By their numbers in this assay, from the lowest: compounds 4, 1, 2 and 3 (each within the scatter of the next).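

In this assay, the 3-chlorophenyl group on the amine nitrogen shows that the number stays within the scatter when a chlorine-bearing ring replaces each of the three earlier rings: a 1.5-fold lower number from compound 3 to compound 4 (0.18 log units; within the scatter) and a 1.1-fold lower number from compound 2 to compound 4 (0.03 log units; within the scatter) and a 1.0-fold lower number from compound 1 to compound 4 (0.02 log units; within the scatter) are all within it. The flat picture at this position thus extends beyond the 4-substituted phenyl groups to a 3-substituted one. Nothing available gives a reason for this. Going by these compounds, it remains open whether a ring bearing a carboxylic acid or an amine, or a plain alkyl chain in place of the phenyl ring, would stay within the same scatter.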